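Lactam for aminooxazole on the fused core

The source may report more compounds than this note shows. Statements on the series, on what has been measured and on what is new or still open speak of the compounds shown alone.

Measured in an ADME assay on microsomes from liver (Homo sapiens) for metabolic stability, read by LC-MS, using NADPH, with stated times of 5 min and 30 min, tested at 1 uM; on this read-out higher numbers stand for fast clearance and lower numbers for slow clearance:
compound 1 `CN(c1ncco1)c1cnc(NCc2c(F)ccc3c2CCO3)n2cnnc12`: 11 mL.min-1.g-1
compound 2 `Cn1nccc1-c1cnc(NCc2c(F)ccc3c2CCO3)c2cn[nH]c(=O)c12`: 14 mL.min-1.g-1

For the measured compounds named here, only two compounds have numbers here, and compound 1 and compound 2 fall within the scatter of each other, so neither can be set apart from the other in this assay.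

Compound 3 `C[C@H]1CC(=O)N(c2cnc(NCc3c(F)ccc4c3CCO4)n3cnnc23)C1` differs from compound 1 by 4-methyl-2-oxopyrrolidin-1-yl in place of methyl(1,3-oxazol-2-yl)amino on an aromatic carbon. Going by the values given here, no pair of measured compounds carries this kind of change, so there is nothing to size it from.

The step of a 1.1-fold lower number from compound 1 to compound 3 (0.04 log units; within the scatter) is therefore expected to stay within the scatter. Compound 3 is estimated at 10 mL.min-1.g-1, with a range of 4 mL.min-1.g-1 to 22 mL.min-1.g-1.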

Compound 3, intrinsic clearance in microsomes: < 3 mL.min-1.g-1
Compound 3: only a limit was reported; the forecaster's own chance of this, stated with the estimate: 10%; middle value at least 3.3-fold (0.52 log units) away from the limit.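

In this assay, for the compounds shown here, 4-methyl-2-oxopyrrolidin-1-yl in place of methyl(1,3-oxazol-2-yl)amino gives an at least 3.6-fold lower number from compound 1 to compound 3 (0.56 log units; beyond the scatter), the first step beyond the scatter and the first sign that the group on this aromatic carbon can move clearance. For compound 3, the reading of < 3 mL.min-1.g-1 is a limit, not a number. The full size of the step stays unknown because of that limit: the limit of < 3 mL.min-1.g-1 in this assay, at which 1 of the 3 values shown sits.

Whether the ring or its methyl accounts for the step stays open. So does how an unsubstituted pyrrolidin-2-one or an open-chain acetamide would read at this carbon.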